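Cytotoxicity notes on the shared core: compound 1 to compound 4

The source may report more compounds than this note shows. Statements on the series, on what has been measured and on what is new or still open speak of the compounds shown alone.

Measured so far:
compound 1 `O=C(NCC1CCCCC1)c1cccc(/C=C2\CC(=O)N(c3ccccc3)C2=O)c1` gives > 100000 nM in an ADME assay on NCM460 cells (Homo sapiens) for cytotoxicity, read by MTT assay, with a stated time of 72 h; a lower number here means a stronger inhibitor, a higher number a weaker inhibitor.
compound 2 `CCCCCN1C(=O)C/C(=C\c2cccc(C(=O)NCCCC)c2)C1=O` gives > 100000 nM in this assay.
compound 3 `Cc1ccc(N2C(=O)C/C(=C\c3cccc(C(=O)Nc4ccc(Cl)cc4)c3)C2=O)cc1` gives > 100000 nM in this assay.

Each of these readings is a limit of this assay, not a number. Compound 1 therefore stands at the limit of > 100000 nM in this assay, at which 3 of the 3 values shown sit, with no separation from compound 2 or compound 3. Compound 4 `O=C(NCc1ccccc1)c1cccc(/C=C2\CC(=O)N(c3ccccc3)C2=O)c1` has not yet been measured; it differs from compound 1 by phenyl in place of cyclohexyl on a saturated chain carbon bound to an amide-type nitrogen. Within the data shown here, no step between measured compounds is available, so the expected size of the step in this assay is none beyond the scatter, and the most likely outcome for compound 4 is again a limit. Compound 4 is thus expected to give 120000 nM, within 50000 nM to 300000 nM. The expected step that the limit leaves unreadable from compound 1 to compound 4 is flat.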

Compound 4, half-maximal inhibitory concentration: > 100000 nM
Compound 4: no number, only a limit; the forecaster's own chance of this, stated with the estimate: 85%; the middle value is on the limit's open side.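

Compound 1 and compound 4 both read only as limits, so no step can be read between them: the limit of > 100000 nM in this assay, at which 4 of the 4 values shown sit.

The compounds shown leave open what separates phenyl from cyclohexyl in this assay, and whether any compound in this series has a measurable half-maximal inhibitory concentration there.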